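Swapping fluoro for isopropyl: what happens to solubility

A few compounds are considered here, and "the series" means these few. Any claim that something is new, unique, unknown or untested is made for them only; others in the source may bear on it.

Measured so far:
- Compound 1 `CCc1ccccc1Nc1ncc2cc(Oc3ccnc(C(=O)NC)c3)ccc2n1`: in a physicochemical assay for solubility, at pH 7 (on this read-out lower numbers stand for lower solubility and higher numbers for higher solubility), compound 1 gives < 1000 nM.
- Compound 2 `CNC(=O)c1cc(Oc2ccc3nc(Nc4ccc(F)cc4)ncc3c2)ccn1`: in this assay compound 2 gives < 1000 nM.

The value of compound 1 is a limit of the assay, not a number. The value of compound 2 is likewise a limit. The step that the two limits leave unreadable from compound 1 to compound 2 therefore cannot be read, as the limit of < 1000 nM in this assay, at which 2 of the 2 values shown sit, shows.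

Compound 3 `CNC(=O)c1cc(Oc2ccc3nc(Nc4ccc(C(C)C)cc4)ncc3c2)ccn1` is not yet measured. It differs from compound 2 by isopropyl in place of fluoro on an aromatic carbon. Among the compounds with values here, no measured step bears directly on this change; the only measured step, a step that the two limits leave unreadable from compound 1 to compound 2, gives no size. Both known values sit at the limit described by the limit of < 1000 nM in this assay, at which 2 of the 2 values shown sit, so no direction beyond the scatter can be claimed. Compound 3 is expected to stay in the same region, estimated at 300 nM (30 nM to 1500 nM), an expected step that the limit leaves unreadable from compound 2 to compound 3 in this assay.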

Compound 3, solubility: < 1000 nM
Compound 3: no number, only a limit; the forecaster's own chance of this, stated with the estimate: 75%; the middle value is on the limit's open side.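

In this assay compound 3 gives < 1000 nM and this is a limit, not a number. No step between compound 1, compound 2 and compound 3 can therefore be read, since all three sit at the same limit: the limit of < 1000 nM in this assay, at which 3 of the 3 values shown sit.
On these data alone, the actual solubility of each compound, and whether the three differ at all, stays open.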